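A few compounds are considered here, and "the series" means these few. Any claim that something is new, unique, unknown or untested is made for them only; others in the source may bear on it.

Of the compounds shown here, three have been read so far in a functional assay on A-375 cells (Homo sapiens) for inhibition, read by CCK-8 assay, with a stated time of 72 h, tested at 2 uM; on this read-out higher numbers stand for more inhibition of growth at the one concentration tested and lower numbers for less inhibition of growth. Compound 1 `Cc1cc(C)cc(SCc2ccc(/C=C/C(=O)Nc3ccccc3N)cc2)c1` gives 8.78% and compound 2 `Nc1ccccc1NC(=O)/C=C/c1ccc(CSc2ccc(Cl)cc2)cc1` gives 13.4% on this read-out. Compound 3 `COc1ccc(SCc2ccc(C(=O)Nc3ccccc3N)cc2)cc1` gives 10.2% and stands within the scatter of both compound 1 and compound 2, so the three values do not separate.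

The next compound is compound 4 `Nc1ccccc1NC(=O)c1ccc(CSc2ccc(Br)cc2)cc1`, which differs from compound 3 by one change: bromo in place of methoxy on an aromatic carbon. In words, bromo takes the place of methoxy on an aromatic carbon, and the rest of the structure stays the same.

Going by the values given here, only one measured step bears on this, and only indirectly. It is a number 4.6 percentage points higher from compound 1 to compound 2 (within the scatter) with 4-chlorophenyl in place of 3,5-dimethylphenyl on a sulfur, and it stays within the scatter. Among the compounds with values here, that pair shares a core that differs from the core of compound 3, and no measured compound carries a bromo, so the evidence is thin. A change of the aryl group on sulfur has so far not moved this assay beyond the scatter, so no step beyond the scatter is expected here.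

The estimated step is a number 2.8 percentage points higher from compound 3 to compound 4 (within the scatter) and this expectation carries no firm direction. For compound 4 the expected value is 13% with an estimated range of 4% to 28% on this read-out.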

Compound 4, percent growth inhibition at one concentration: 4.35%
For compound 4 the middle estimate is 8.7 percentage points above the measured one, within the range that was stated.
By their numbers in this assay, from the lowest: compounds 4, 1, 3 and 2 (each within the scatter of the next).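

Working notes on the position para to a large group: with bromo in place of methoxy on an aromatic carbon, this assay gives a number 5.9 percentage points lower from compound 3 to compound 4 (within the scatter), the first measured exchange at this position on the core of compound 3. The 4-methoxyphenyl and 4-bromophenyl forms therefore do not separate on this read-out, although they differ in heavy atoms and in hydrogen-bond acceptors, with methoxy counting one acceptor and bromo none. No measurement on hand bears on the reading of this pair, and it stands as an observation only.

Open is whether an amine or a carboxylic acid at this same position on the core of compound 3 would give a step beyond the scatter, since both groups shown here leave the reading within it. Also open is whether bromo and methoxy would read alike on the core of compound 1, where the pair shown so far carries 4-chlorophenyl and 3,5-dimethylphenyl on the sulfur.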